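A few compounds are considered here, and "the series" means these few. Any claim that something is new, unique, unknown or untested is made for them only; others in the source may bear on it.

Of the compounds shown here, three have been measured in an ADME assay on microsomes from liver (Homo sapiens) for metabolic stability; a lower number here means that the compound disappears faster, a higher number that the compound lasts longer. For compound 1 `CCC(/C=C1\OC(=O)NC1=O)(CC)c1ccc(-c2ccc3cc(F)cc(F)c3c2)[nH]c1=O` this assay gives only a limit, > 3 h, not a number. Compound 2 `O=C1NC(=O)/C(=C/C(c2ccc(-c3ccc4cccc(F)c4c3)[nH]c2=O)C2CCCCC2)O1` gives 1.09 h in this assay, and compound 3 `CC(C)C(c1ccc(-c2ccc3cccc(F)c3c2)[nH]c1=O)C1C(=O)NC(=O)N1C` gives 0.375 h, the lowest of the two numbers, with compound 2 standing higher by a gap that exceeds the usual scatter. Compound 4 `CC(C)C(/C=C1/C(=O)NC(=O)N1C)c1ccc(-c2ccc3cccc(F)c3c2)[nH]c1=O` has not yet been measured. It differs from compound 3 in one place: a group of 9 heavy atoms (5 carbon, 2 nitrogen, 2 oxygen; one five-membered non-aromatic ring with 2 hetero atoms) in place of a group of 8 heavy atoms (4 carbon, 2 nitrogen, 2 oxygen; one five-membered non-aromatic ring with 2 hetero atoms), on a saturated chain carbon bound to an aromatic carbon and a saturated chain carbon. For the measured compounds named here, no pair of measured compounds shares this change, so the size of the step can only be expected, not read off. The expected step is upward, beyond the scatter, to a longer half-life: a 2.7-fold higher number from compound 3 to compound 4 (0.43 log units; beyond the scatter). Compound 4 is accordingly estimated at 1 h, within a range from 0.4 h to 2.5 h.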

Compound 4, half-life: > 3 h
Compound 4 gave a limit, no number; the forecaster's own chance of this, stated with the estimate: 10%; middle value at least 3.0-fold (0.47 log units) from the limit.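

On the saturated chain carbon bound to an aromatic carbon and a saturated chain carbon, replacing 3-methyl-2,5-dioxoimidazolidin-4-yl with the group holding one more carbon and one more double bond outside aromatic rings gives, in this assay, an at least 8.0-fold higher number from compound 3 to compound 4 (0.90 log units; beyond the scatter). For the compounds shown here, this is the first step that can be read at this position. Compound 4 gives a limit, not a number, so the step's full size stays unknown: the limit of > 3 h in this assay, at which 2 of the 4 values shown sit.

The compounds shown cannot separate the extra carbon from the extra double bond. As far as these compounds go, how a carboxylic acid or a primary amide would fare at this place also stays open.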